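The source may report more compounds than this note shows. Statements on the series, on what has been measured and on what is new or still open speak of the compounds shown alone.

Measured so far in a physicochemical assay for lipophilicity, read by LC-MS, in phosphate buffer, measured as octanol-water partition, with a stated time of 30 min, at pH 7.4, tested at 200 mM; a lower number here means a more polar compound, a higher number a more lipophilic compound:

Compound 1 `Cn1c(COc2cccc(C(=O)O)c2)nc2ccc(Oc3ccc(Cl)c(F)c3)nc21` — 2.2
Compound 2 `Cc1ccc(Oc2ccc3nc(COc4cccc(C(=O)O)c4)n(C)c3n2)cc1F` — 2.1
Compound 3 `Cn1c(COc2cccc(C(=O)O)c2)nc2ccc(Oc3cccc(Cl)n3)cc21` — 1.2

Compound 3 stands lowest of the three numbers in this assay. Its nearest neighbour is compound 2, whose value lies higher by a margin beyond the scatter, and compound 1 lies higher still, also beyond the scatter. Going by the values given here, the one measured step, a number 0.10 log units lower from compound 1 to compound 2 (within the scatter), falls within the scatter.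

The next compound in the series is compound 4 `Cc1cc(F)cnc1Oc1ccc2nc(COc3cccc(C(=O)O)c3)n(C)c2c1`, which has not yet been measured in this assay. It differs from compound 3 in one place:

5-fluoro-3-methylpyridin-2-yl in place of 6-chloropyridin-2-yl on an oxygen on an aromatic ring

Among the compounds with values here, the only measured step that bears on this change is the one from compound 1 to compound 2, where methyl in place of chloro on an aromatic carbon left the number essentially unchanged. Within the data shown here, in compound 4 the chloro is likewise lost while a methyl enters, and a fluoro enters as well; no measured pair shows that addition on its own. Taken together, the step from compound 3 to compound 4 is expected to be small, a number 0.10 log units higher from compound 3 to compound 4 (within the scatter), probably within or near the scatter. Compound 4 is therefore expected to give about 1.3 in this assay. The range for compound 4 is estimated to run from 0.9 to 1.8.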

Compound 4, distribution coefficient: 1.1
Beside the measured number, compound 4's estimate is 0.20 log units above it, within the range that was stated.
By their numbers in this assay, from the lowest: compounds 4 and 3 (each within the scatter of the next); then compounds 2 and 1 (each within the scatter of the next).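

In this assay the exchange of 6-chloropyridin-2-yl for 5-fluoro-3-methylpyridin-2-yl on an oxygen on an aromatic ring reads as a number 0.10 log units lower from compound 3 to compound 4 (within the scatter) and thus shows that the whole substituent at this place, with 7 heavy atoms leaving and 8 heavy atoms entering, can change while the number stays inside the scatter. Going by these compounds alone, the earlier pair covered only one group on an aromatic carbon, with a number 0.10 log units lower from compound 1 to compound 2 (within the scatter) as its step, whereas here the chloro leaves and a methyl and a fluoro enter together, while both substituents remain one six-membered aromatic ring with 1 hetero atom and the same hydrogen-bond donor and acceptor counts. No measured evidence available here explains why this step stays so small.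

The compounds shown do not separate the methyl from the fluoro, so the contribution of each to the step remains unknown, and the two may or may not offset each other. As far as these compounds go, it also remains open whether the number would hold with an amine on this ring, or with a longer alkyl chain in place of the ring on the same oxygen.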